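Flipping One Ring Centre: Expected Stability of Compound 4

The source may report more compounds than this note shows. Statements on the series, on what has been measured and on what is new or still open speak of the compounds shown alone.

Compound 1, `CN(C[C@H]1Cc2c(cccc2N[C@H]2CC[C@H](N)CC2)CN1)[C@H]1CCCc2cccnc21`: 100%
Compound 2, `CN(C)C1CCN(c2cccc3c2C[C@H](CN(C)[C@H]2CCCc4cccnc42)NC3)CC1`: 78.4%
Compound 3, `CN(C)[C@@H]1CCN(c2cccc3c2C[C@H](CN(C)[C@H]2CCCc4cccnc42)NC3)C1`: "not determined" (no result reported)
Compound 4, `CN(C)[C@H]1CCN(c2cccc3c2C[C@H](CN(C)[C@H]2CCCc4cccnc42)NC3)C1`: to be measured

Going by the values given here, in an ADME assay on microsomes from liver (Homo sapiens) for metabolic stability, using NADPH, with a stated time of 10 min (on this read-out higher numbers stand for a more stable compound and lower numbers for a less stable compound), compound 1 gives 100% and compound 2 gives 78.4%; the only measured step is a number 21.6 percentage points lower from compound 1 to compound 2 (beyond the scatter). Compound 3 has no number in this assay, its entry being "not determined" (no result reported), so it cannot be placed on the scale at all. Compound 4 differs from compound 3 in one place only: the two compounds have the same atoms and bonds and differ only in configuration as drawn: 1 of 3 stereo elements differ; a stereocentre at a saturated ring carbon is drawn R in compound 3 and S in compound 4. Among the compounds with values here, none of the measured steps concerns a change of configuration alone, so neither direction nor size can be drawn from them, and compound 2 is the nearest measured point for a compound of this kind. The value of compound 4 in this assay is estimated at 75%, expected to lie between 50% and 95%.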

Compound 4, percent of the compound remaining: 67.5%
Compound 4: middle estimate off by 7.5 percentage points, on the high side; measured number inside the range.
By their numbers in this assay, from the lowest: compound 4; then compound 2; then compound 1.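

In this assay, the position on the aromatic carbon proves sensitive even to a change between two dimethylamino-bearing rings: 3-(dimethylamino)pyrrolidin-1-yl in place of 4-(dimethylamino)piperidin-1-yl gives a number 10.9 percentage points lower from compound 2 to compound 4 (beyond the scatter). Set against the (4-aminocyclohexyl)amino group, the same pyrrolidine gives a number 32.5 percentage points lower from compound 1 to compound 4 (beyond the scatter), a larger step than the one to the piperidine seen earlier.

The effect of the flipped ring centre alone cannot be read, as compound 3 has no number, although that pair would isolate it: the fact that compounds 3 and 4 differ only in the configuration as drawn. Going by these compounds, how a morpholin-4-yl group would behave on this aromatic carbon also remains open.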